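A few compounds are considered here, and "the series" means these few. Any claim that something is new, unique, unknown or untested is made for them only; others in the source may bear on it.

Measured so far:
- compound 1, `C=C(C)[C@@H]1CC=C(Cn2cc(COc3cc(C4NC(=O)NC(C)=C4C(=O)OCC)ccc3OC)nn2)CC1`: > 100000 nM
- compound 2, `C=C(C)[C@@H]1CC=C(Cn2cc(COc3cccc(C4NC(=O)NC(C)=C4C(C)=O)c3)nn2)CC1`: > 100000 nM

In a functional assay on NCI/ADR-RES cells (Homo sapiens) for inhibition, read by sulforhodamine B assay, with a stated time of 48 h (a lower number here means a stronger inhibitor of growth, a higher number a weaker inhibitor of growth), compound 1 gives a limit, > 100000 nM, not a number. In this assay compound 2 likewise gives only a limit, > 100000 nM. For the measured compounds named here, compound 2 therefore stands at the limit of > 100000 nM in this assay, at which 2 of the 2 values shown sit; no measured step separates it from compound 1, and the two values show only that neither compound reaches a measurable concentration for total growth inhibition within the tested range.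

The next compound in the series is compound 3, `C=C(C)[C@@H]1CC=C(Cn2cc(COc3cc(C4NC(=O)NC(C)=C4C(C)=O)ccc3OC)nn2)CC1`. It differs from compound 2 in one place: methoxy in place of hydrogen on an aromatic carbon. Going by the values given here, no measured pair in this set isolates that change, so nothing in the numbers speaks for an effect of it in either direction. The step that the limit leaves unreadable from compound 2 to compound 3 is expected to be none beyond the scatter, given that compound 2 sits at the limit of > 100000 nM in this assay, at which 2 of the 2 values shown sit, and that compound 1, which already carries the methoxy, gives the same limit > 100000 nM.

Compound 3 is expected to give about 150000 nM, within 40000 nM to 600000 nM, most likely reported again as a limit rather than a number.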

Compound 3, concentration for total growth inhibition: 84900 nM
Estimate against measurement, compound 3: 1.8-fold (0.25 log units) above; the range from low to high includes it.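

In this assay, for the compounds shown here, compound 3 gives 84900 nM, the only actual number among the three compounds, and it carries both the methoxy on the aromatic carbon and the methyl on the carbonyl carbon. The series shows an at least 1.1-fold lower number from compound 2 to compound 3 (0.07 log units; that floor lies within the scatter) for methoxy in place of hydrogen, and an at least 1.1-fold lower number from compound 1 to compound 3 (0.07 log units; that floor lies within the scatter) for methyl in place of ethoxy; both are floors, so the true size of either step remains unknown, and neither change is shown to act beyond the scatter. The other two values remain limits, so the number for compound 3 has no measured partner: the limit of > 100000 nM in this assay, at which 2 of the 3 values shown sit.

Still open, on these data alone, is whether either change has a real effect in this assay, since a number for compound 3 set against limits cannot separate a small step from a large one. Also open, as far as these compounds go, is whether an amine or a carboxylic acid in place of the methoxy, or a longer chain in place of the methyl on the carbonyl carbon, would bring the value well clear of the limit.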